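This account rests on a few compounds, and the source may have more. Where it says the series, first, only, none or still open, it means among the compounds named here.

Working notes on the series. Compound 1 `CCCCN(CCCC)c1ccc(C(=O)C2CC2c2ccc(Cl)cc2)cc1` in an ADME assay on Vero cells (Chlorocebus sabaeus) for cytotoxicity, with a stated time of 72 h (on this read-out lower numbers stand for higher toxicity in this test and higher numbers for lower toxicity in this test), gives 431 ug/mL, and compound 2 `CCCCCCCCCCCCCCCCNc1ccc(C(=O)C2CC2c2ccc(Cl)cc2)cc1` in this assay gives 410 ug/mL; the two numbers sit within the usual scatter of each other, so neither stands apart. Compound 3 `O=C(c1ccc(NCCO)cc1)C1CC1c1ccc(Cl)cc1` is the next member and is not yet measured. It differs from compound 1 by (2-hydroxyethyl)amino in place of dibutylamino on an aromatic carbon. Among the compounds with values here, no measured pair in this set shows such a change, so nothing here sets the size of the step. The step from compound 1 to compound 3 in this assay is expected to be small, a 1.0-fold higher number from compound 1 to compound 3 (0.02 log units; within the scatter), with no direction beyond the scatter. For compound 3 in this assay the estimate is 450 ug/mL, ranging from 200 ug/mL to 1000 ug/mL.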

Compound 3, half-maximal cytotoxic concentration: 305 ug/mL
For compound 3 the middle estimate is 1.5-fold (0.17 log units) above the measured one; low and high end bracket the measured number.
By their numbers in this assay, from the lowest: compounds 3, 2 and 1 (each within the scatter of the next).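

Placing (2-hydroxyethyl)amino in place of dibutylamino on an aromatic carbon gives a 1.4-fold lower number from compound 1 to compound 3 (0.15 log units; within the scatter) in this assay. At this position, then, exchanging a larger group without hydrogen-bond donors for a smaller one with them leaves the read-out within the scatter. No measured data on the compounds bear on the reason for this result. From the compounds shown here alone, whether a primary amine, a carboxylic acid or a morpholine at this position would move the number beyond the scatter stays open.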